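Fluorophenyl series: the step from compound 2 to compound 3

A few compounds are considered here, and "the series" means these few. Any claim that something is new, unique, unknown or untested is made for them only; others in the source may bear on it.

In a functional assay on HCT-8 cells (Homo sapiens) (on this read-out higher numbers stand for an effect only at larger amounts of compound and lower numbers for an effect already at smaller amounts), compound 1 `COc1cc2nc(-c3ccccc3F)nc(O)c2cc1OC` gives 17 ug/mL. Compound 2 `COc1cc2nc(-c3cccc(F)c3)nc(O)c2cc1OC` is reported only as a limit, > 20 ug/mL, and has no number of its own. Compound 2 therefore stands at the limit of > 20 ug/mL in this assay, at which 1 of the 2 values shown sits.

Compound 3 `COc1cc2nc(-c3ccc(F)cc3)nc(O)c2cc1OC` differs from compound 2 as follows: 4-fluorophenyl in place of 3-fluorophenyl on an aromatic carbon. The 4-fluorophenyl enters on an aromatic carbon of the same six-membered aromatic ring with 2 nitrogen, and the rest of the shared core stays unchanged.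

Going by the values given here, one measured step bears on this change: an at least 1.1-fold higher number from compound 1 to compound 2 (0.07 log units; that floor lies within the scatter). That step is open-ended, so it offers a floor and not a size. Among the compounds with values here, nothing measured so far points to a clear direction for the new change, so no shift beyond the scatter is expected in this assay. The expected change is a step that the limit leaves unreadable from compound 2 to compound 3, and it is expected to stay within the scatter. A report of compound 3 as a limit alone would fit this expectation equally well.

For compound 3 the estimated value is 22 ug/mL, with an expected range of 12 ug/mL to 40 ug/mL.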

Compound 3, concentration for half-maximal effect: > 20 ug/mL
Compound 3 ended at the assay's limit (the forecaster's own chance of this, stated with the estimate: 60%); the middle value is on the limit's open side.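

In this assay the 4-fluorophenyl gives the same kind of result as the 3-fluorophenyl: compound 3 is reported only as a limit, > 20 ug/mL, so the step between compound 2 and compound 3 cannot be read. Against compound 1, the only compound here with a number of its own, the change gives an at least 1.1-fold higher number from compound 1 to compound 3 (0.07 log units; that floor lies within the scatter), which sets a floor and not a size. The fluorophenyl series now sits largely at the limit of the read-out: the limit of > 20 ug/mL in this assay, at which 2 of the 3 values shown sit.

Still open, as far as these compounds go, is whether compound 2 and compound 3 differ at all, and whether compound 1 truly stands apart from them by more than the scatter. Also open, from the compounds shown here alone, is how this assay responds when an amine or a carboxylic acid takes the place of the fluorine on the phenyl ring, or when a longer chain takes the place of the fluorophenyl on the shared core.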